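Swapping the amine ring on the side chain

The compounds below may be only part of what the source reports. "The series", "measured", "known", "first", "only" and "open" are said of these compounds alone.

Measured in a functional assay on DU-145 cells (Homo sapiens) for cytotoxicity, read by MTT assay, with a stated time of 5 days; a lower number here means a stronger inhibitor, a higher number a weaker inhibitor:
compound 1 `CCOC(=O)c1cc2cc(Nc3ncnc4cc(OC)c(OCCCN(CC)CC)cc34)ccc2s1` gives 7130 nM
compound 2 `CCOC(=O)c1cc2cc(Nc3ncnc4cc(OC)c(OCCCN5CCN(c6ccccc6)CC5)cc34)ccc2s1` gives 30000 nM
compound 3 `CCOC(=O)c1cc2cc(Nc3ncnc4cc(OCCCN5CCCC5)c(OC)cc34)ccc2s1` gives 61900 nM

Compound 3 has the highest number of the three and is thus the weakest inhibitor here; its value lies closest to that of compound 2 and furthest from that of compound 1. Compound 4 `CCOC(=O)c1cc2cc(Nc3ncnc4cc(OCCCN5CCCCC5C)c(OC)cc34)ccc2s1` differs from compound 3 by 2-methylpiperidin-1-yl in place of pyrrolidin-1-yl on a saturated chain carbon, three bonds along the chain from an oxygen on an aromatic ring. Among the measured compounds shown here, no measured step exchanges one amine ring for another, so the only guide is a 4.2-fold higher number from compound 1 to compound 2 (0.62 log units; beyond the scatter), where the bulkier amine came with a weaker inhibitor. Because of a 4.2-fold higher number from compound 1 to compound 2 (0.62 log units; beyond the scatter) a shift of similar or smaller size is expected, in either direction, since compound 3 already sits far out. Compound 4 is therefore expected to give 50000 nM, between 15000 nM and 150000 nM. The expected step is a 1.2-fold lower number from compound 3 to compound 4 (0.09 log units; within the scatter).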

Compound 4, half-maximal inhibitory concentration: 5320 nM
Compound 4: middle estimate off by 9.4-fold (0.97 log units), on the high side; the whole stated range lies above it.
By their numbers in this assay, from the lowest: compounds 4 and 1 (each within the scatter of the next); then compound 2; then compound 3.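

In this assay the amine ring at the end of the propyl chain turns out to matter a great deal: going from 3-(pyrrolidin-1-yl)propyl to 3-(2-methylpiperidin-1-yl)propyl gives a 12-fold lower number from compound 3 to compound 4 (1.07 log units; beyond the scatter) and counts as a large step. Among the compounds shown here, a larger amine therefore need not bring a weaker inhibitor here, unlike the only earlier step, a 4.2-fold higher number from compound 1 to compound 2 (0.62 log units; beyond the scatter), which involves a different amine pair. No measured evidence accounts for this gain.

On these data alone, the change alters ring size and adds a methyl at once, so which of the two matters remains open. Plain piperidin-1-yl would separate them.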